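The source may hold more compounds than are shown below. What is called first, only, known or untested is meant among the compounds shown, and "the series" means these compounds.

Among the compounds with values here, in an ADME assay for pharmacokinetics, in phosphate buffer, with a stated time of 0.25 h, tested at 60 uM, at a dose of 60 microM (a lower number here means less compound in the circulation, a higher number more compound in the circulation at the dose given), three compounds have numbers so far. Compound 1 `Cc1ccc(NC(=S)OCCNC(=O)C(C)(C)Oc2ccc(Cl)cc2)cc1` gives 15800 nM. Compound 2 `CC(C)(Oc1ccc(Cl)cc1)C(=O)Oc1ccc(-c2cc(=S)ss2)cc1` gives 11400 nM, and compound 3 `NC(=S)c1ccc(OC(=O)c2cccnc2)cc1` gives 18100 nM. Compound 1 stands second highest of the three numbers; its nearest neighbour is compound 3, whose number sits within the scatter of it, and its furthest is compound 2, whose number also lies within the scatter. On these numbers alone, then, the three compounds cannot be separated in this assay.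

Compound 4 `CC(C)(Oc1ccc(Cl)cc1)C(=O)NCCOC(=S)Nc1ccc(F)cc1` has not yet been measured. It differs from compound 1 in a single place: fluoro in place of methyl on an aromatic carbon. Within the data shown here, no pair of measured compounds shares this change, so the measured set gives no direction for it, and the three measured compounds, which differ from one another in many places at once, all fall within the scatter of one another. The step from compound 1 to compound 4 in this assay is therefore expected to be small, with no direction preferred, and no larger than the scatter: a 1.1-fold lower number from compound 1 to compound 4 (0.02 log units; within the scatter) is the estimate. Compound 4 is accordingly expected to give about 15000 nM, with a likely range from 7500 nM to 30000 nM.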

Compound 4, maximal plasma concentration: 16900 nM
Beside the measured number, compound 4's estimate is 1.1-fold (0.05 log units) below it; measured number inside the range.
By their numbers in this assay, from the lowest: compounds 2, 1, 4 and 3 (each within the scatter of the next).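

Within the data shown here, the pair of compound 1 and compound 4 gives the first reading of a single change in this assay, where the earlier compounds differed from one another in many places at once. Among these compounds, with fluoro in place of methyl on an aromatic carbon, para to a large group, the result is a 1.1-fold higher number from compound 1 to compound 4 (0.03 log units; within the scatter), so this read-out does not separate the 4-methylphenyl and 4-fluorophenyl forms of the shared core, and at this position the exchange of these two groups, each of a single heavy atom, leaves no step that can be told from the scatter. Nothing at hand bears on why the two compounds read alike, and no explanation can be drawn from the data shown.

The compounds shown leave open whether a different group at this position, such as an amine, a carboxylic acid or a methoxy group, would give a step beyond the scatter, as only methyl and fluoro appear there. Among the compounds shown here, they also leave open whether fluoro in place of methyl would read the same way on another core, as this one pair is the only example of the change.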